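A few compounds are considered here, and "the series" means these few. Any claim that something is new, unique, unknown or untested is made for them only; others in the source may bear on it.

In a functional assay on HeLa cells (Homo sapiens) for inhibition, read by CCK-8 assay, with a stated time of 48 h (on this read-out higher numbers stand for weaker inhibition and lower numbers for stronger inhibition), compound 1, `COc1ccc(NC(=O)NCCNS(=O)(=O)c2ccc(-c3ccccc3OCc3ccccc3)s2)cc1`, gives > 50000 nM, which is a limit of the assay and not a number. Compound 2, `COc1cccc(NC(=O)NCCNS(=O)(=O)c2ccc(-c3ccccc3OCc3ccccc3)s2)c1`, gives > 50000 nM, also a limit. Compound 3, `O=S(=O)(NCCNC(=S)Nc1ccc(Cl)cc1)c1ccc(-c2ccccc2OCc2ccccc2)s1`, gives a true number, 7000 nM. The measured steps are a step that the two limits leave unreadable from compound 1 to compound 2, an at least 7.1-fold lower number from compound 1 to compound 3 (0.85 log units; beyond the scatter) and an at least 7.1-fold lower number from compound 2 to compound 3 (0.85 log units; beyond the scatter). All three changes lie on a nitrogen side of the molecule, and none touches the oxygen that carries the benzyl group. Compound 4, `COc1ccc(NC(=O)NCCNS(=O)(=O)c2ccc(-c3ccccc3Oc3ccc([N+](=O)[O-])c([N+](=O)[O-])c3)s2)cc1`, differs from compound 1 by 3,4-dinitrophenyl in place of benzyl on an oxygen on an aromatic ring. The two readable steps therefore serve only as a loose guide to how far a single change can move the number. The expected result is an at least 1.4-fold lower number from compound 1 to compound 4 (0.15 log units; that floor lies within the scatter), a modest move at best and in the direction of stronger inhibition. For compound 4 the estimated value is 35000 nM, with an expected range from 8000 nM to 80000 nM.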

Compound 4, half-maximal inhibitory concentration: > 20000 nM
Compound 4 gave a limit, no number (the forecaster's own chance of this, stated with the estimate: 50%); the middle value is on the limit's open side.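

Compound 4 gives > 20000 nM, a limit of the assay. Compound 1 gives > 50000 nM, also a limit, so the step between compound 1 and compound 4 cannot be read. From the compounds shown here alone, whether 3,4-dinitrophenyl in place of benzyl moves the number at all stays open.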